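Adding a Second Methoxy Group to the Styryl Ring

A few compounds are considered here, and "the series" means these few. Any claim that something is new, unique, unknown or untested is made for them only; others in the source may bear on it.

This study covers three measured vinyl sulfones and one that is not yet measured. Compound 2 `COc1ccc(CS(=O)(=O)/C=C/c2ccccc2OC)cc1` is tested in a functional assay on DLD-1 cells (Homo sapiens) for antiproliferative activity, read by trypan blue exclusion (a lower number here means a stronger inhibitor, a higher number a weaker inhibitor), where compound 2 gives 7500 nM. Compound 1 `COc1cc(OC)c(/C=C/S(=O)(=O)Cc2ccc(Cl)cc2)c(OC)c1` gives 15000 nM in this assay, and compound 3 `COc1ccc(CS(=O)(=O)/C=C/c2ccc(F)cc2OC)cc1` gives 15000 nM, so both neighbours sit within the usual scatter of compound 2, and no order among the three can be read from these numbers.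

Compound 4 `COc1ccc(CS(=O)(=O)/C=C/c2c(OC)cccc2OC)cc1` differs from compound 2 by a single change: methoxy in place of hydrogen on an aromatic carbon. The new group sits on an aromatic carbon of a six-membered aromatic ring of carbon only, ortho to a large group and meta to a methoxy group.

Among the compounds with values here, only one measured step touches the same ring: a 2.0-fold higher number from compound 2 to compound 3 (0.30 log units; within the scatter), which stayed within the scatter. Compound 1 carries three methoxy groups on its styryl ring and a different benzyl part, so its value next to compound 2 shows only that the two lie close together. On this basis compound 4 is expected to show no step beyond the scatter, and a 1.3-fold higher number from compound 2 to compound 4 (0.12 log units; within the scatter) is the estimated change. Compound 4 is therefore estimated at 10000 nM, with a range from 4000 nM to 30000 nM.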

Compound 4, half-maximal inhibitory concentration: 700 nM
For compound 4 the middle estimate is 14-fold (1.15 log units) above the measured one; measured number below the stated range.
By their numbers in this assay, from the lowest: compound 4; then compounds 2, 1 and 3 (each within the scatter of the next).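

In this assay, within the data shown here, methoxy in place of hydrogen on this aromatic carbon, ortho to a large group and meta to a methoxy group, gives the first step in this set that lies beyond the scatter (an 11-fold lower number from compound 2 to compound 4 (1.03 log units; beyond the scatter)). Among these compounds, the only earlier step on this ring, fluoro in place of hydrogen (a 2.0-fold higher number from compound 2 to compound 3 (0.30 log units; within the scatter)), stayed within the scatter, so the earlier compounds gave no sign that a single change on this ring could move the number this far. No measurement offered here accounts for the size of the step, so the result stands as an observation and carries no explanation.

The compounds shown leave open whether the step belongs to methoxy itself or would also appear with a hydroxyl group, a methyl group, a chlorine atom or an amine on this same carbon. They also leave open whether a longer chain such as ethoxy would keep the step, and whether the same change would give a similar step with a different benzyl part or on other cell lines.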